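The compounds below may be only part of what the source reports. "The series", "measured", "known", "first", "only" and "open" are said of these compounds alone.

Three measured compounds share one core and differ only in the group on an aromatic carbon. In an assay on CHO cells for antagonist activity at transient receptor potential cation channel subfamily V member 1 (Homo sapiens), read by FLIPR (on this read-out lower numbers stand for stronger inhibition and higher numbers for weaker inhibition), compound 1 `CC(C(=O)NCc1ccc(C(F)(F)F)cc1N1CCN(c2ccccc2)CC1)c1ccc(NS(C)(=O)=O)c(F)c1` gives 2 nM, compound 2 `CC(C(=O)NCc1ccc(C(F)(F)F)cc1OC1CCCC1)c1ccc(NS(C)(=O)=O)c(F)c1` gives 0.6 nM, and compound 3 `CC(C)CCSc1cc(C(F)(F)F)ccc1CNC(=O)C(C)c1ccc(NS(C)(=O)=O)c(F)c1` gives 1.4 nM. Compound 3 stands second highest of the three: the step of a 1.4-fold lower number from compound 1 to compound 3 (0.15 log units; within the scatter) lies within the scatter, while a 2.3-fold higher number from compound 2 to compound 3 (0.37 log units; beyond the scatter) is a modest shift. Compound 4 `CC(C(=O)NCc1ccc(C(F)(F)F)cc1-c1ccc(C(C)(C)C)cc1)c1ccc(NS(C)(=O)=O)c(F)c1` is not yet measured; it differs from compound 3 in that (4-(tert-butyl)phenyl in place of isopentylsulfanyl on an aromatic carbon). Within the data shown here, no measured step involves an aromatic ring entering at this position, so the shifts a 3.3-fold lower number from compound 1 to compound 2 (0.52 log units; beyond the scatter) and a 2.3-fold higher number from compound 2 to compound 3 (0.37 log units; beyond the scatter) give only a sense of scale. Compound 4 is therefore expected to give 2.5 nM in this assay, between 0.6 nM and 10 nM, a step of a 1.8-fold higher number from compound 3 to compound 4 (0.25 log units; within the scatter) that may well lie within the scatter.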

Compound 4, inhibition constant: 1.1 nM
Beside the measured number, compound 4's estimate is 2.3-fold (0.36 log units) above it; the measured number falls inside the stated range.
By their numbers in this assay, from the lowest: compounds 2, 4, 3 and 1 (each within the scatter of the next, the first and the last beyond it).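

The step of a 1.3-fold lower number from compound 3 to compound 4 (0.10 log units; within the scatter) shows that an aromatic ring can enter at this position, as 4-(tert-butyl)phenyl, with no shift beyond the scatter. The steps of a 1.8-fold higher number from compound 2 to compound 4 (0.26 log units; within the scatter) and a 1.8-fold lower number from compound 1 to compound 4 (0.26 log units; within the scatter) are also within the scatter, so compound 4 lies within the scatter of compound 1 and compound 2, although those two lie beyond it from each other. No evidence is available to explain why these different groups read so alike.

The compounds shown leave open whether an unsubstituted phenyl would read the same, and whether an amine or a carboxylic acid on the ring in place of tert-butyl would hold this level.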